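The source may hold more compounds than are shown below. What is called first, only, known or untested is meant among the compounds shown, and "the series" means these compounds.

Measured so far in a functional assay on A549 cells (Homo sapiens) for cytotoxicity; a lower number here means a stronger inhibitor, a higher number a weaker inhibitor:
- compound 1, `C=C/C=C\[C@H](C)[C@H](OC(N)=O)[C@@H](C)[C@H](O)[C@@H](C)C/C(C)=C\[C@H](C)[C@@H](O)[C@@H](C)/C=C\CCc1cccc(F)c1`: 650 nM
- compound 2, `C=C/C=C\[C@H](C)[C@H](OC(N)=O)[C@@H](C)[C@H](O)[C@@H](C)C/C(C)=C\[C@H](C)[C@@H](O)[C@@H](C)/C=C\CCc1cccc(Cl)c1`: 580 nM

Compound 2 gives the lowest number of the two shown, but the only step in the set, a 1.1-fold lower number from compound 1 to compound 2 (0.05 log units; within the scatter), is within the scatter, so the two compounds are not separated by these numbers.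

Compound 3, `C=C/C=C\[C@H](C)[C@H](OC(N)=O)[C@@H](C)[C@H](O)[C@@H](C)C/C(C)=C\[C@H](C)[C@@H](O)[C@@H](C)/C=C\CCc1ccccc1`, is not yet measured. Its difference from compound 2 is computed as hydrogen in place of chloro on an aromatic carbon.

Among the compounds with values here, the one measured step that bears on this change is the swap of one halogen for another on this aromatic carbon, a 1.1-fold lower number from compound 1 to compound 2 (0.05 log units; within the scatter), which lay within the scatter. Within the data shown here, nothing in the set distinguishes fluoro from chloro here, and there is no measured compound with hydrogen in this place. On that basis the expected step of a 1.2-fold higher number from compound 2 to compound 3 (0.08 log units; within the scatter) is none beyond the scatter, with a wide range because the unsubstituted ring has no direct comparison among the measured compounds.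

For compound 3 the estimate in this assay is 700 nM, expected to fall between 300 nM and 1600 nM.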

Compound 3, half-maximal inhibitory concentration: 510 nM
The estimate for compound 3 lay 1.4-fold (0.14 log units) above the measured number; the range from low to high includes it.
By their numbers in this assay, from the lowest: compounds 3, 2 and 1 (each within the scatter of the next).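

In this assay hydrogen in place of chloro on this aromatic carbon gives a 1.1-fold lower number from compound 2 to compound 3 (0.06 log units; within the scatter) and hydrogen in place of fluoro gives a 1.3-fold lower number from compound 1 to compound 3 (0.11 log units; within the scatter) so the unsubstituted phenyl now provides a measured reference that the two halogen compounds alone could not supply. Hydrogen, fluoro and chloro are not separated by these numbers, which means that, among these three compounds, a halogen at this place is not required for cytotoxicity at the level they show. No evidence is available here to explain this flat result.

From the compounds shown here alone, what remains open is whether any group on this aromatic carbon can shift the number beyond the scatter, since the three atoms compared here span only a narrow set, and an amine, a methoxy group or a carboxylic acid would test the position more severely. Also open, going by these compounds, is whether a shorter or longer chain in place of phenethyl, or a halogen on another carbon of the ring, would separate compounds where these substitutions do not.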